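The source may report more compounds than this note shows. Statements on the series, on what has been measured and on what is new or still open speak of the compounds shown alone.

Measured so far:
- compound 1, `COc1ccccc1/C=C/C(=O)c1ccc(OCC(=O)N[C@H]2CCOC2=O)cc1`, 7240 nM
- compound 2, `CC(C)c1ccc(/C=C/C(=O)c2ccc(OCC(=O)N[C@H]3CCOC3=O)cc2)cc1`, 4660 nM
- compound 3, `O=C(COc1ccc(C(=O)/C=C/c2ccccc2)cc1)N[C@H]1CCOC1=O`, 56800 nM

The read-out throughout is a functional assay on PC-3 cells (Homo sapiens) for antiproliferative activity, read by MTT assay, with a stated time of 72 h; on this read-out higher numbers stand for weaker inhibition and lower numbers for stronger inhibition. Compound 3 carries the bare phenyl on the double-bonded chain and stands highest of the three numbers; its nearest neighbour is compound 1, a 7.8-fold higher number from compound 1 to compound 3 (0.89 log units; beyond the scatter), and its furthest compound 2, a 12-fold higher number from compound 2 to compound 3 (1.09 log units; beyond the scatter). Between compounds 1 and 2 the difference is small, a 1.6-fold lower number from compound 1 to compound 2 (0.19 log units; within the scatter).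

Compound 4, `O=C(COc1ccc(C(=O)/C=C/c2cccc([N+](=O)[O-])c2)cc1)N[C@H]1CCOC1=O`, is not yet measured. It differs from compound 3 by nitro in place of hydrogen on an aromatic carbon, placed on an aromatic carbon of the six-membered carbon ring, meta to a large group.

The two steps that bear on this change both run from a substituted phenyl to the bare one and both raise the number, modestly for methoxy and largely for isopropyl. The reverse direction, putting a substituent onto the bare phenyl of compound 3, is therefore expected to lower the number in this assay. Nitro is a different group from either methoxy or isopropyl, and it enters at a different place on the ring, so the expected step is kept smaller than the two measured ones and its range wide: a 3.8-fold lower number from compound 3 to compound 4 (0.58 log units; beyond the scatter). Compound 4 is estimated at 15000 nM, between 4000 nM and 50000 nM.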

Compound 4, half-maximal inhibitory concentration: 56300 nM
Compound 4: middle estimate off by 3.8-fold (0.57 log units), on the low side; the whole stated range lies below it.
By their numbers in this assay, from the lowest: compounds 2 and 1 (each within the scatter of the next); then compounds 4 and 3 (each within the scatter of the next).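

In this assay, nitro on the bare phenyl, on an aromatic carbon meta to a large group, gives no step beyond the scatter: a 1.0-fold lower number from compound 3 to compound 4 (0.00 log units; within the scatter). A substituent on this ring therefore does not by itself bring the lower numbers of the methoxy and isopropyl compounds, and compound 4 goes against that reading, with a 12-fold higher number from compound 2 to compound 4 (1.08 log units; beyond the scatter) and a 7.8-fold higher number from compound 1 to compound 4 (0.89 log units; beyond the scatter). No measurement at hand explains this result.

The compounds shown do not separate the group from its place: 3-nitrophenyl is the only nitro ring here, and methoxy and isopropyl stand at other places on the ring. On these data alone, whether an amine or a carboxylic acid on the same aromatic carbon would match nitro also remains open.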